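A few compounds are considered here, and "the series" means these few. Any claim that something is new, unique, unknown or untested is made for them only; others in the source may bear on it.

Compound 1 `O=C(Nc1cccc(-n2cc(-c3ccncc3)c(-c3cc(O)cc(Cl)c3)n2)c1)Nc1ccc(Cl)c(C(F)(F)F)c1`: in a functional assay on K562 cells (Homo sapiens) for inhibition, read by sulforhodamine B assay, with a stated time of 48 h, tested at 100 uM (a higher number here means a weaker effect of the compound at the concentration tested, a lower number a stronger effect), compound 1 gives -9%
Compound 2 `O=C(Nc1cccc(-n2cc(-c3ccncc3)c(-c3cc(O)cc(Cl)c3)n2)c1)Nc1ccc(Cl)c(Cl)c1`: in this assay compound 2 gives 5%

Among these two numbers compound 1 stands lowest; its nearest neighbour is compound 2, reached by the step of a number 14 percentage points higher from compound 1 to compound 2 (beyond the scatter). Going by the values given here, that step concerns a chloro in place of a trifluoromethyl on an aromatic carbon, a different part of the molecule from the one that changes next.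

Compound 3 `COc1cc(Cl)cc(-c2nn(-c3cccc(NC(=O)Nc4ccc(Cl)c(C(F)(F)F)c4)c3)cc2-c2ccncc2)c1` differs from compound 1 by methyl in place of hydrogen on an oxygen on an aromatic ring. Among the compounds with values here, no measured step touches this oxygen: the only step known, a number 14 percentage points higher from compound 1 to compound 2 (beyond the scatter), lies elsewhere and says nothing about a methyl on the hydroxy. With no comparable step to lean on, the account has no reason to expect a move beyond the scatter in this assay in either direction, and the uncertainty is correspondingly broad. Compound 3 is therefore expected to stay close to compound 1, with an expected step of a number 7 percentage points higher from compound 1 to compound 3 (within the scatter). The estimate for compound 3 in this assay is -2%, within a range from -25% to 30%.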

Compound 3, a percentage reported as activity, at one concentration (the size of the read-out at that concentration, not a potency): -51%
For compound 3 the middle estimate is 49 percentage points above the measured one; measured number outside the range, below it.
By their numbers in this assay, from the lowest: compound 3; then compound 1; then compound 2.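

Replacing the hydroxy with methoxy, that is, 3-chloro-5-hydroxyphenyl with 3-chloro-5-methoxyphenyl, gives in this assay a number 42 percentage points lower from compound 1 to compound 3 (beyond the scatter), the first view of what this oxygen can do. A methyl of a single heavy atom placed on an oxygen on an aromatic ring thus produces a large step, whereas the earlier change at the other end of the molecule gave only the modest a number 14 percentage points higher from compound 1 to compound 2 (beyond the scatter), and since a lower number means a stronger effect here, the hydrogen on this oxygen is not required for the effect at the concentration tested. The compounds shown offer no measurement that accounts for the size of this step.

From the compounds shown here alone, it remains open whether an ethoxy group or a longer chain on this oxygen would extend the step or reverse it, and whether an amine in place of the hydroxy would behave like the methoxy group. Also unresolved is whether the methoxy step would carry over to the dichlorinated ring of compound 2, and, as this read-out comes from one concentration, whether the stronger effect would hold at other concentrations.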